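The source may hold more compounds than are shown below. What is called first, only, known or untested is meant among the compounds shown, and "the series" means these compounds.

Compound 1 `COc1ccc(C(=O)N2CCN(Cc3nc4ccccc4n3Cc3cccc(C)c3)CC2)cc1`: 55.5%
Compound 2 `O=C(C1CC1)N1CCN(Cc2nc3ccccc3n2Cc2ccccc2)CC1`: 23.9%

Of the compounds shown here, two have been measured in an assay on isolated protein for inhibition of aldehyde dehydrogenase 1A1 (Homo sapiens), read by spectrophotometry, tested at 10 uM; a lower number here means less inhibition, a higher number more inhibition at the concentration tested (going by the name of the read-out). Compound 1 `COc1ccc(C(=O)N2CCN(Cc3nc4ccccc4n3Cc3cccc(C)c3)CC2)cc1` gives 55.5%, the higher of the two numbers; compound 2 `O=C(C1CC1)N1CCN(Cc2nc3ccccc3n2Cc2ccccc2)CC1` gives 23.9%, and the gap between them lies beyond the usual scatter. Compound 3 `CC(=O)N1CCN(Cc2nc3ccccc3n2Cc2cccc(C)c2)CC1` has not yet been measured. It differs from compound 1 by methyl in place of 4-methoxyphenyl on a carbonyl carbon. Compound 2 also carries something other than 4-methoxyphenyl on the carbonyl carbon, but it differs from compound 1 in a second place as well, so its value only hints at the direction. A downward step, beyond the scatter, is expected for a number 25.5 percentage points lower from compound 1 to compound 3 (beyond the scatter). Compound 3 is expected to give 30%, in the range 10% to 52%.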

Compound 3, a percentage reported as inhibition, at one concentration (the size of the read-out at that concentration, not a potency): 70.3%
For compound 3 the middle estimate is 40.3 percentage points below the measured one; measured number outside the range, above it.
By their numbers in this assay, from the lowest: compound 2; then compound 1; then compound 3.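

In this assay, methyl in place of 4-methoxyphenyl on the carbonyl carbon gives a number 14.8 percentage points higher from compound 1 to compound 3 (beyond the scatter). At this position, then, the six-membered aromatic ring of the 4-methoxyphenyl group is not required for inhibition at the concentration tested, and the much smaller acetyl group carries more of it. Nothing available explains this step.

Still open, from the compounds shown here alone, is how a longer chain such as butyl, or an amine such as dimethylamino, would behave on that carbonyl carbon. Also open, going by these compounds, is whether an unsubstituted phenyl would track compound 1 or compound 3.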